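One More Chloro on the Weakest Aryl Thioether

This account rests on a few compounds, and the source may have more. Where it says the series, first, only, none or still open, it means among the compounds named here.

Measured compounds in an assay on isolated protein for inhibition of Amine oxidase [flavin-containing] B (Homo sapiens); on this read-out lower numbers stand for stronger inhibition and higher numbers for weaker inhibition:
- Compound 1 `C#CCNC1CCc2c(SCCc3cccc(Cl)c3)cccc21` gives 82400 nM
- Compound 2 `C#CCNC1CCc2c(OCc3cccc(C(F)(F)F)c3)cccc21` gives 6410 nM
- Compound 3 `C#CCNC1CCc2c(SCc3ccc(OC)cc3)cccc21` gives 1900 nM

Of the three measured compounds, compound 1 has the highest number in this assay, so it is the weakest inhibitor of the set. The gap to compound 2 is beyond the usual scatter, and the gap to compound 3 is wider still, so the order is reliable.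

Compound 4 `C#CCNC1CCc2c(SCCc3ccc(Cl)c(Cl)c3)cccc21` has not yet been measured. It differs from compound 1 in one place: chloro in place of hydrogen on an aromatic carbon, which reads, one bond further out, as 3-chlorophenyl to 3,4-dichlorophenyl.

Going by the values given here, no pair among the measured compounds shows what this particular change does, so there is no directly comparable step to lean on. Only a modest step is expected, with a slight lean toward a lower number; the expected step from compound 1 to compound 4 is a 2.1-fold lower number from compound 1 to compound 4 (0.31 log units; beyond the scatter). Compound 4 is therefore estimated at 40000 nM, within a range from 10000 nM to 150000 nM.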

Compound 4, half-maximal inhibitory concentration: 3850 nM
Compound 4: middle estimate off by 10-fold (1.02 log units), on the high side, and the stated range ends above it.
By their numbers in this assay, from the lowest: compound 3; then compounds 4 and 2 (each within the scatter of the next); then compound 1.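

Within this assay the step is large: a 21-fold lower number from compound 1 to compound 4 (1.33 log units; beyond the scatter) comes with chloro in place of hydrogen on an aromatic carbon, ortho to a chloro group and para to a large group. Going by these compounds alone, this carbon is therefore far from indifferent to substitution, since one added heavy atom, with no ring and no net charge, moves the number well beyond the scatter, which the earlier compounds could not show because none of them formed a one-place pair. Nothing available here explains why the 3,4-dichlorophenyl group outdoes the 3-chlorophenyl group.

Going by these compounds, whether a fluoro, a methyl or a methoxy on this same carbon would give a step of similar size remains open. So does whether the added chloro would do as much on a longer chain.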